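Title: Removing the trifluoromethyl group from compound 3

This account rests on a few compounds, and the source may have more. Where it says the series, first, only, none or still open, it means among the compounds named here.

Compound 3, `O=C(C1CC1)N1CCN(Cc2nc3ccccc3n2Cc2ccc(C(F)(F)F)cc2)CC1`, has the lowest number of the three measured compounds in an assay on isolated protein for inhibition of aldehyde dehydrogenase 1A1 (Homo sapiens), read by spectrophotometry, tested at 10 uM; a lower number here means less inhibition, a higher number more inhibition at the concentration tested (going by the name of the read-out): compound 3 gives 37%. Its closest neighbour is compound 2, `Cc1ccc(Cn2c(CN3CCN(C(=O)C4CC4)CC3)nc3ccccc32)cc1`, which in this assay gives 51.5%; the gap is a number 14.5 percentage points lower from compound 2 to compound 3 (beyond the scatter), brought about by trifluoromethyl in place of methyl on an aromatic carbon. Furthest away stands compound 1, `CC(C)=CCn1c(CN2CCN(C(=O)C3CC3)CC2)nc2ccccc21`, with 74.3% in this assay, and the step is a number 37.3 percentage points lower from compound 1 to compound 3 (beyond the scatter), with 4-(trifluoromethyl)phenyl in place of 2-methylprop-1-en-1-yl on a saturated chain carbon bound to an aromatic nitrogen.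

Compound 4, `O=C(C1CC1)N1CCN(Cc2nc3ccccc3n2Cc2ccccc2)CC1`, differs from compound 3 in one place: hydrogen in place of trifluoromethyl on an aromatic carbon. Going by the values given here, the step that bears most directly on this change is the one from compound 2 to compound 3, where swapping methyl for trifluoromethyl cost a number 14.5 percentage points lower from compound 2 to compound 3 (beyond the scatter). Going the other way, from trifluoromethyl to hydrogen, is expected to recover a similar modest amount, placing compound 4 in this assay near compound 2 rather than near compound 1, since the step from compound 1 to compound 2 shows that an aryl group on that chain carbon already sits well under the alkenyl of compound 1. The expected step is therefore a number 11 percentage points higher from compound 3 to compound 4 (beyond the scatter), upward. Compound 4 is thus estimated at 48% in this assay, within a range from 34% to 62%.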

Compound 4, a percentage reported as inhibition, at one concentration (the size of the read-out at that concentration, not a potency): 23.9%
Compound 4: the middle estimate sits 24.1 percentage points above what was measured; the whole stated range lies above it.
By their numbers in this assay, from the lowest: compound 4; then compound 3; then compound 2; then compound 1.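

In this assay, the unsubstituted ring turns out to be the low point at this position: hydrogen in place of trifluoromethyl gives a number 13.1 percentage points lower from compound 3 to compound 4 (beyond the scatter), and hydrogen in place of methyl gives a number 27.6 percentage points lower from compound 2 to compound 4 (beyond the scatter), so both groups carry a higher number than hydrogen, methyl the more so. The earlier step between methyl and trifluoromethyl only ranked those two groups against each other; with hydrogen added, it appears that in this series either group on that aromatic carbon goes with more inhibition at the concentration tested than no group at all. The distance from the alkenyl side chain also grows, since phenyl in place of 2-methylprop-1-en-1-yl gives a number 50.4 percentage points lower from compound 1 to compound 4 (beyond the scatter), which places the plain phenyl further from compound 1 than either substituted ring.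

Nothing among the information given accounts for this order. As far as these compounds go, it remains open whether other groups at this position, such as methoxy, chlorine or an amine, would also stand above hydrogen, and whether any aryl group could come near the alkenyl chain of compound 1.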